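Swapping a cyanophenyl for a fluorophenyl: lipophilicity outlook

A few compounds are considered here, and "the series" means these few. Any claim that something is new, unique, unknown or untested is made for them only; others in the source may bear on it.

Measured so far:
- compound 1, `CNC(=O)c1cc(C(=O)NC2CC2)cn(CC2CCCOC2)c1=O`: 2
- compound 2, `CNC(=O)c1cc(C(=O)NC2CC2)cn(Cc2nccc3[nH]ccc23)c1=O`: 1.7
- compound 3, `CNC(=O)c1cc(C(=O)NC2CC2)cn(Cc2cccc(C#N)c2)c1=O`: 2.6

In a physicochemical assay for lipophilicity, at pH 7.4 (a higher number here means a more lipophilic compound, a lower number a more polar compound), compound 3 gives the highest of the three numbers. Its nearest neighbour is compound 1, with the step of a number 0.60 log units higher from compound 1 to compound 3 (beyond the scatter); the furthest is compound 2, with the step of a number 0.90 log units higher from compound 2 to compound 3 (beyond the scatter). Between compound 1 and compound 2 the step of a number 0.30 log units lower from compound 1 to compound 2 (within the scatter) is within the scatter.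

Compound 4, `CNC(=O)c1cc(C(=O)NC2CC2)cn(Cc2ccccc2F)c1=O`, differs from compound 3 in one place: 2-fluorophenyl in place of 3-cyanophenyl on a saturated chain carbon bound to an aromatic nitrogen. Within the data shown here, no measured step involves 2-fluorophenyl, so the expectation rests on the measured steps into compound 3, which show that the group on this saturated chain carbon moves the number by modest amounts, and on the counted difference, in which the leaving group carries one hydrogen-bond acceptor and the entering group none. A modest rise in this assay is therefore expected, as the step of a number 0.50 log units higher from compound 3 to compound 4 (beyond the scatter). Compound 4 is estimated at 3.1, within 2.6 to 3.6.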

Compound 4, distribution coefficient: 3
Beside the measured number, compound 4's estimate is 0.10 log units above it; the measured number falls inside the stated range.
By their numbers in this assay, from the lowest: compounds 2 and 1 (each within the scatter of the next); then compound 3; then compound 4.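

In this assay, the group on the saturated chain carbon bound to an aromatic nitrogen can raise the number beyond what 3-cyanophenyl gives: the swap to 2-fluorophenyl makes a number 0.40 log units higher from compound 3 to compound 4 (beyond the scatter) and so sets a new top for the series. Among these compounds, the same group also widens the spread at this place, with a number 1.00 log units higher from compound 1 to compound 4 (beyond the scatter) and, the only large step seen here, a number 1.30 log units higher from compound 2 to compound 4 (beyond the scatter) at the far end. Nothing measured alongside these numbers explains the effect of this swap.

The swap changes both the group and where it sits on the phenyl ring, and the compounds shown cannot tell these two changes apart. A plain phenyl or a 3-fluorophenyl would separate them, while an amine on this chain carbon's ring remains an open question for the lower end of the range.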